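The source may report more compounds than this note shows. Statements on the series, on what has been measured and on what is new or still open speak of the compounds shown alone.

Measured compounds and their readings:

compound 1 `COC(=O)/C=C/CNC(=O)c1c[nH]c2ccc(Br)cc12`: > 25000 nM
compound 2 `CC1=CC(C)(C)Nc2c(C(=O)N[C@@H](C)/C=C/S(C)(=O)=O)cccc21`: > 25000 nM
compound 3 `C[C@@H]1CC(C)(C)Nc2c(C(=O)NC/C=C/S(C)(=O)=O)cccc21`: > 25000 nM

In an ADME assay on N2a cells (Mus musculus) for cytotoxicity (on this read-out higher numbers stand for lower toxicity in this test and lower numbers for higher toxicity in this test), compound 1 gives > 25000 nM, which is a limit of the assay and not a number. Compound 2 gives > 25000 nM in this assay, again a limit rather than a number. Compound 3 gives > 25000 nM in this assay, also a limit. Compound 2 therefore stands at the limit, and so does every other reading shown, because of the limit of > 25000 nM in this assay, at which 3 of the 3 values shown sit.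

Compound 4 `CC1=CC(C)(C)Nc2c(C(=O)NC/C=C/S(C)(=O)=O)cccc21` has not yet been measured in this assay. It differs from compound 2 by hydrogen in place of methyl on a saturated chain carbon bound to an amide-type nitrogen and a double-bonded chain carbon. Among the compounds with values here, no step between measured compounds is known here, so the direction of this change cannot be read from a measured pair. With every reading at the limit, compound 4 is expected to show no step beyond the scatter, and the step that the limit leaves unreadable from compound 2 to compound 4 is estimated as flat. In this assay compound 4 is expected to give about 30000 nM, most likely reported again only as a limit, within a range of 15000 nM to 100000 nM.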

Compound 4, half-maximal cytotoxic concentration: 27000 nM
For compound 4 the middle estimate is 1.1-fold (0.05 log units) above the measured one, and the stated range covers the measured number.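

No step can be read from compound 2 to compound 4 in this assay, since the reading of compound 2 is a limit and not a number: the limit of > 25000 nM in this assay, at which 3 of the 4 values shown sit.

The compounds shown leave open whether hydrogen in place of methyl on that saturated chain carbon changes the reading in this assay at all.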